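The source may hold more compounds than are shown below. What is called first, only, known or untested is meant among the compounds shown, and "the series" means these compounds.

Compound 1 `C=C1C[C@]23C[C@@]1(O)CC[C@H]2c1ccc(OS(=O)(=O)c2ccc(C)cc2)c(C)c1[C@@H]3Cn1cc(-c2ccc(Cl)cc2)nn1` — in a functional assay on HL-60 cells (Homo sapiens) for cytotoxicity, read by MTT assay, with a stated time of 4 days (a lower number here means a stronger inhibitor, a higher number a weaker inhibitor), compound 1 gives > 20000 nM, which is a limit of the assay and not a number.
Compound 2 `C=C1C[C@]23C[C@@]1(O)CC[C@H]2c1cc(Br)c(O)c(C)c1[C@@H]3Cn1cc(-c2ccccn2)nn1` — in this assay compound 2 gives > 20000 nM, again a limit.
Compound 3 `C=C1C[C@]23C[C@@]1(O)CC[C@H]2c1ccc(O)c(C)c1[C@@H]3Cn1cc(-c2ccc(Cl)cc2)nn1` — in this assay compound 3 gives > 20000 nM, also a limit.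

Compound 1 therefore stands at the limit of this assay, and so do the two other measured compounds: the limit of > 20000 nM in this assay, at which 3 of the 3 values shown sit, summarises that every value shown sits there. Among the compounds with values here, the only step between two compounds that differ in a single place, a step that the two limits leave unreadable from compound 1 to compound 3, cannot be read in size, since both ends are limits.

Compound 4 `C=C1C[C@]23C[C@@]1(O)CC[C@H]2c1ccc(OS(=O)(=O)c2ccc(C)cc2)c(C)c1[C@@H]3Cn1cc(-c2ccccn2)nn1` differs from compound 1 by pyridin-2-yl in place of 4-chlorophenyl on an aromatic carbon. Within the data shown here, no measured step bears directly on this change. Compound 2 carries the same pyridin-2-yl group on its triazole and it, too, reached only the limit. Taken together, the measured compounds offer no sign that any change shown so far brings a readable value in this assay.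

Compound 4 is therefore expected to come out at 30000 nM, with a range from 20000 nM to 100000 nM. The step that the limit leaves unreadable from compound 1 to compound 4 is expected to be unreadable, with compound 4 most likely reported only as a limit.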

Compound 4, half-maximal inhibitory concentration: > 20000 nM
Compound 4: a limit, no number (the forecaster's own chance of this, stated with the estimate: 85%); the middle value does not contradict the limit.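

In this assay compound 4 gives > 20000 nM, which is a limit of the assay and not a number. Compound 1 also stands at a limit, so the size of the step between compound 1 and compound 4 cannot be read. The compounds shown leave open whether any change to the shared core would bring a readable value, as every result sits at the same limit: the limit of > 20000 nM in this assay, at which 4 of the 4 values shown sit.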